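This account rests on a few compounds, and the source may have more. Where it says the series, first, only, none or still open, it means among the compounds named here.

In a functional assay on HL-60 cells (Homo sapiens) for cytotoxicity, read by ELISA, with a stated time of 2 days (a lower number here means a stronger inhibitor, a higher number a weaker inhibitor), compound 1 (`Oc1cccc(-c2cc(-c3ccccc3)cc(-c3cccs3)n2)c1`) gives 14100 nM and compound 2 (`Oc1cccc(-c2cc(-c3ccccc3)cc(-c3ccco3)n2)c1`) gives 9910 nM, two values within the scatter of each other. Compound 3 (`Oc1cccc(-c2cc(-c3ccccc3)cc(-c3cccc(O)c3)n2)c1`) carries 3-hydroxyphenyl in place of furan-2-yl on an aromatic carbon. Among the compounds with values here, the one measured step bearing on this place is a 1.4-fold lower number from compound 1 to compound 2 (0.15 log units; within the scatter), an exchange between two five-membered rings. Within the data shown here, no measured step covers a six-membered ring here, so only a weak expectation of no shift beyond the scatter follows. The expected change is a 1.1-fold lower number from compound 2 to compound 3 (0.04 log units; within the scatter). For compound 3 the estimated value is 9000 nM, with an expected range from 3000 nM to 27000 nM.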

Compound 3, half-maximal inhibitory concentration: 16400 nM
Beside the measured number, compound 3's estimate is 1.8-fold (0.26 log units) below it; measured number inside the range.
By their numbers in this assay, from the lowest: compounds 2, 1 and 3 (each within the scatter of the next).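

With a 1.7-fold higher number from compound 2 to compound 3 (0.22 log units; within the scatter) and a 1.2-fold higher number from compound 1 to compound 3 (0.07 log units; within the scatter) in this assay, this position takes a six-membered aromatic ring bearing a hydrogen-bond donor in place of either five-membered ring without a shift beyond the scatter. The tolerance seen earlier between furan-2-yl and thiophen-2-yl therefore extends to 3-hydroxyphenyl, a larger group. No evidence is available that explains this result. The compounds shown leave open whether an amine or a carboxylic acid at this place would give a number beyond the scatter. They also leave open how plain phenyl or 4-hydroxyphenyl would compare with 3-hydroxyphenyl.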